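Adding a Second Chlorine to a Weakly Active Pair

The compounds below may be only part of what the source reports. "The series", "measured", "known", "first", "only" and "open" are said of these compounds alone.

Compound 1, `Cn1c(N2N=C(c3ccc(Cl)cc3)CC2c2ccccc2)nc(-c2ccccc2)c(C#N)c1=O`, and compound 2, `Cn1c(N2N=C(c3ccccc3)CC2c2ccccc2)nc(-c2ccc(Cl)cc2)c(C#N)c1=O`, share one core and differ only in which of their two aromatic rings carries a chlorine. In a functional assay on HT-29 cells (Homo sapiens) for antiproliferative activity, with a stated time of 72 h (on this read-out lower numbers stand for stronger inhibition and higher numbers for weaker inhibition), compound 1 gives 6600 nM, while compound 2 gives 19500 nM, the higher of the two numbers, and the gap to compound 1 lies beyond the scatter. Compound 3, `Cn1c(N2N=C(c3ccc(Cl)cc3)CC2c2ccccc2)nc(-c2ccc(Cl)cc2)c(C#N)c1=O`, carries both chlorines: chloro in place of hydrogen on an aromatic carbon, on an aromatic carbon para to a large group. Going by the values given here, no measured pair shows this change on its own, so the step of a 2.4-fold lower number from compound 2 to compound 3 (0.39 log units; beyond the scatter) is only an expectation of a moderate fall. Compound 3 is expected to give about 8000 nM, within 3000 nM to 25000 nM.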

Compound 3, half-maximal inhibitory concentration: 8720 nM
Estimate against measurement, compound 3: 1.1-fold (0.04 log units) below; the measured number falls inside the stated range.
By their numbers in this assay, from the lowest: compounds 1 and 3 (each within the scatter of the next); then compound 2.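

In this assay, the change from phenyl to 4-chlorophenyl can now be read at two places on the shared core, and the two readings differ. At one place it gives a modest gain, a 2.2-fold lower number from compound 2 to compound 3 (0.35 log units; beyond the scatter), while at the other it gives no clear change, a 1.3-fold higher number from compound 1 to compound 3 (0.12 log units; within the scatter). Nothing measured here accounts for this contrast. The compounds shown leave open how a group other than chloro, such as methoxy or an amine, would behave at either place.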